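Replacing the 4-(hydroxycarbamoyl)butyl group of compound 2

This account rests on a few compounds, and the source may have more. Where it says the series, first, only, none or still open, it means among the compounds named here.

Compound 1 `CCOc1cc(C(C)(C)C)ccc1C1=NC(c2ccc(Cl)cc2)C(c2ccc(Cl)cc2)N1C(=O)N1CCN(Cc2ccc(C(=O)NO)cc2)CC1` gives 2170 nM
Compound 2 `CCOc1cc(C(C)(C)C)ccc1C1=NC(c2ccc(Cl)cc2)C(c2ccc(Cl)cc2)N1C(=O)N1CCN(CCCCC(=O)NO)CC1` gives 3780 nM

In a functional assay on A549 cells (Homo sapiens) for antiproliferative activity, read by CCK-8 assay, with a stated time of 72 h (on this read-out lower numbers stand for stronger inhibition and higher numbers for weaker inhibition), compound 2 gives 3780 nM and stands within the scatter of compound 1, so the two cannot be ranked. Compound 3 (`CCOc1cc(C(C)(C)C)ccc1C1=NC(c2ccc(Cl)cc2)C(c2ccc(Cl)cc2)N1C(=O)N1CCN(c2ncc(C(=O)NO)cn2)CC1`) has not yet been measured. It carries 5-(hydroxycarbamoyl)pyrimidin-2-yl in place of 4-(hydroxycarbamoyl)butyl on an amine nitrogen in a ring. Among the measured compounds shown here, the only measured step that bears on this change is a 1.7-fold higher number from compound 1 to compound 2 (0.24 log units; within the scatter), where 3-(hydroxycarbamoyl)propyl replaces 4-(hydroxycarbamoyl)phenyl on a saturated chain carbon bound to an amine nitrogen in a ring. That exchange of an aromatic ring for a chain stayed within the scatter. For the measured compounds named here, no measured compound has an aromatic ring on the amine nitrogen itself, so this precedent is only partial and the range is kept wide. In this assay no step beyond the scatter is expected, and the estimated change is a 1.5-fold lower number from compound 2 to compound 3 (0.18 log units; within the scatter) as the central expectation. For compound 3 the estimated value is 2500 nM, with an expected range from 900 nM to 7000 nM.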

Compound 3, half-maximal inhibitory concentration: 1970 nM
Compound 3: middle estimate off by 1.3-fold (0.10 log units), on the high side, within the range that was stated.
By their numbers in this assay, from the lowest: compounds 3, 1 and 2 (each within the scatter of the next).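

In this assay, 5-(hydroxycarbamoyl)pyrimidin-2-yl on the amine nitrogen in a ring gives a small step when it takes the place of 4-(hydroxycarbamoyl)butyl (a 1.9-fold lower number from compound 2 to compound 3 (0.28 log units; within the scatter)) and a smaller one when it takes the place of 4-(hydroxycarbamoyl)benzyl (a 1.1-fold lower number from compound 1 to compound 3 (0.04 log units; within the scatter)). Compound 3 is the only one of the three with an aromatic ring bound directly to that nitrogen, so this position now has a measured example of that attachment as well as the two attached through a saturated chain carbon, and neither step separates the new group from the earlier ones. No evidence is at hand on why the three compounds lie so close together.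

As far as these compounds go, all three compounds end in the hydroxycarbamoyl group, so it remains open how this position would respond to a carboxylic acid or a primary amide in its place. From the compounds shown here alone, it also remains open whether a longer chain, or a pyridine ring in place of the pyrimidine, would produce a step beyond the scatter in this assay.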